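Extending the Methyl of Compound 1 to Butyl

The source may hold more compounds than are shown below. What is called first, only, known or untested is meant among the compounds shown, and "the series" means these compounds.

Compound 1, `Cc1cc2ccccc2nc1-c1cn(-c2ccc(F)cc2)nn1`, was tested in a functional assay on U-937 cells (Homo sapiens) for cytotoxicity, read by MTT assay, with a stated time of 24 h (a higher number here means a weaker inhibitor, a lower number a stronger inhibitor), and gives 65.6 ug/mL. Among the measured compounds shown here, it is the only compound with a numerical reading in this assay. Compound 2, `CCCc1cc2ccccc2nc1-c1cn(CCC(F)(F)C(F)(F)C(F)(F)C(F)(F)C(F)(F)C(F)(F)C(F)(F)C(F)(F)F)nn1`, returns in this assay only > 100 ug/mL, which is a limit of the measurement rather than a number. That reading for compound 2 is the limit of > 100 ug/mL in this assay, at which 1 of the 2 values shown sits. For the measured compounds named here, compound 2 differs from compound 1 in more than one place, so no single step between measured compounds can be drawn from these two.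

Compound 3, `CCCCc1cc2ccccc2nc1-c1cn(-c2ccc(F)cc2)nn1`, has not yet been measured in this assay. It differs from compound 1 by propyl in place of hydrogen on a saturated chain carbon bound to an aromatic carbon. Going by the values given here, with no measured step of this kind to draw on, the size of the change is expected to stay within the usual scatter, with no clear direction either way. The step from compound 1 to compound 3 in this assay is therefore expected to be about a 1.1-fold higher number from compound 1 to compound 3 (0.03 log units; within the scatter). Compound 3 is expected to give roughly 70 ug/mL, most likely between 30 ug/mL and 150 ug/mL, with a real chance that this assay reports only a limit for compound 3.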

Compound 3, half-maximal inhibitory concentration: 66.2 ug/mL
For compound 3 the middle estimate is 1.1-fold (0.02 log units) above the measured one, within the range that was stated.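

Among the compounds shown here, the only step measured at this position, propyl in place of hydrogen on a saturated chain carbon bound to an aromatic carbon, reads in this assay as a 1.0-fold higher number from compound 1 to compound 3 (0.00 log units; within the scatter). Compound 2 differs from compound 1 in more than one place and so could not isolate this position, whereas this pair shows that, on the shared core of compound 1, the readings for the methyl and butyl forms cannot be told apart in this cell assay. No measured property among the data shown bears on this result, so it stands as an observation without an explanation.

The compounds shown leave open whether a chain longer than butyl, such as octyl, or an amine or a carboxylic acid in place of the butyl, would also leave the reading where it stands. For the compounds shown here, they also leave open whether the same change would read alike on a compound carrying a different group on the triazole nitrogen than the one in compound 1 and compound 3.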